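The compounds below may be only part of what the source reports. "The series", "measured", "known", "first", "only" and "open" are said of these compounds alone.

Compound 1 `CN(C)CCn1cnnc1-c1cc(Oc2ccc(NC(=O)N/N=C/c3c[nH]c4ccccc34)cc2F)ccn1` and compound 2 `CN(C)CCn1cnnc1-c1cc(Oc2ccc(NC(=O)N/N=C/c3ccc(O)c(Br)c3)cc2F)ccn1` share a core with compound 3 `COc1ccc(/C=N/NC(=O)Nc2ccc(Oc3ccnc(-c4nncn4CCN(C)C)c3)c(F)c2)c(OC)c1OC` and differ from it only in the group on the carbon that carries the double bond to nitrogen. In an ADME assay on WI-38 cells (Homo sapiens) for cytotoxicity, read by MTT assay, with a stated time of 72 h (a higher number here means a weaker inhibitor, a lower number a stronger inhibitor), compound 1 gives 3620 nM, and compound 2 gives 5560 nM; the step of a 1.5-fold higher number from compound 1 to compound 2 (0.19 log units; within the scatter) is the only one on record at that position. In this assay compound 3 gives "not determined" (no result reported), so no number stands for it. Compound 4 `CN(C)CCn1cnnc1-c1cc(Oc2ccc(NC(=O)N/N=C/c3ccc(F)cc3)cc2F)ccn1` differs from compound 3 by 4-fluorophenyl in place of 2,3,4-trimethoxyphenyl on a carbon with a double bond to nitrogen. Going by the values given here, since the one comparable exchange at this position stayed within the scatter, compound 4 is expected to sit near compounds 1 and 2 in this assay, with an estimate of 5000 nM and a range from 2000 nM to 15000 nM.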

Compound 4, half-maximal inhibitory concentration: 3980 nM
For compound 4 the middle estimate is 1.3-fold (0.10 log units) above the measured one; the measured number falls inside the stated range.
By their numbers in this assay, from the lowest: compounds 1, 4 and 2 (each within the scatter of the next).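

In this assay the position now has a third group, and neither step from it leaves the scatter: there is a 1.4-fold lower number from compound 2 to compound 4 (0.15 log units; within the scatter) and also a 1.1-fold higher number from compound 1 to compound 4 (0.04 log units; within the scatter) in this series. The earlier compounds shown here offered one exchange at this position; these steps add 4-fluorophenyl, which has 0 hydrogen-bond donors and 0 hydrogen-bond acceptors, and all three values remain within the scatter of one another. Nothing available here explains why these numbers stay together. Going by these compounds, whether a non-aromatic group at this position, such as an amine, a carboxylic acid or a longer alkyl chain, would give a step beyond the scatter remains open.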